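Cytotoxicity notes on a purine nucleoside pair

A few compounds are considered here, and "the series" means these few. Any claim that something is new, unique, unknown or untested is made for them only; others in the source may bear on it.

Measured so far:
compound 1 `OC[C@H]1O[C@@H](n2cnc3c(NCc4cccc(I)c4)nc(NCCOCc4ccccc4)nc32)[C@H](O)[C@@H]1O` — "not determined" (no result reported)
compound 2 `OC[C@H]1O[C@@H](n2cnc3c(NC4CCCC4)nc(NCCOCc4ccccc4)nc32)[C@H](O)[C@@H]1O` — 78800 nM

In an ADME assay on L6 cells (Rattus norvegicus) for cytotoxicity (a lower number here means a stronger inhibitor, a higher number a weaker inhibitor), compound 2 gives 78800 nM. Going by the values given here, that is the only number in hand, since compound 1 carries no result in this assay, so compound 2 stands alone and nothing can be said about its rank. Compound 3 `COc1nc(NC2CCCC2)c2ncn([C@@H]3O[C@H](CO)[C@@H](O)[C@H]3O)c2n1` is not yet measured. It differs from compound 2 at one place: methoxy in place of (2-(benzyloxy)ethyl)amino on an aromatic carbon. Among the compounds with values here, with no step between two measured compounds available, the size of the change can only be judged from the change itself: a group carrying one ring leaves and a much smaller group with no ring enters. The step expected is a 1.5-fold higher number from compound 2 to compound 3 (0.18 log units; within the scatter), toward weaker inhibition, though it may not exceed the scatter. Compound 3 is estimated at 120000 nM, with a range from 40000 nM to 350000 nM.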

Compound 3, half-maximal inhibitory concentration: 51600 nM
Beside the measured number, compound 3's estimate is 2.3-fold (0.37 log units) above it, within the range that was stated.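

In this assay, methoxy in place of (2-(benzyloxy)ethyl)amino on the aromatic carbon between two ring nitrogen atoms gives a 1.5-fold lower number from compound 2 to compound 3 (0.18 log units; within the scatter) and thus no change that can be told from the scatter. One six-membered aromatic ring of carbon only and the hydrogen-bond donor leave with the larger group, yet compound 2 and compound 3 remain indistinguishable in this assay, so for this pair the read-out does not follow the size of the group at this position. Nothing in hand bears on the reason for this.

Going by these compounds, compound 1 gives "not determined" (no result reported), so its step to compound 2 cannot be read and the role of the other amino substituent stays open. On these data alone, whether a free amine or a longer alkoxy chain on this carbon would move the number beyond the scatter also remains open.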